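A few compounds are considered here, and "the series" means these few. Any claim that something is new, unique, unknown or untested is made for them only; others in the source may bear on it.

Measured in a functional assay on MDA-MB-231 cells (Homo sapiens) for inhibition, read by CCK-8 assay, with a stated time of 48 h; on this read-out lower numbers stand for stronger inhibition of growth and higher numbers for weaker inhibition of growth:
- compound 1 `Cc1ccccc1Nc1nc(Nc2ccc(N3CCN(C)CC3)cn2)ncc1Cl`: 7470 nM
- compound 2 `CN1CCN(c2ccc(Nc3ncc(Cl)c(NCc4ccccc4)n3)nc2)CC1`: 24800 nM
- compound 3 `COc1ccccc1CNc1nc(Nc2ccc(N3CCN(C)CC3)cn2)ncc1Cl`: 29300 nM

Compound 3 sits at the high end of these numbers together with compound 2, and the gap between them, a 1.2-fold higher number from compound 2 to compound 3 (0.07 log units; within the scatter), lies within the scatter. Compound 1 stands apart, with a 3.9-fold higher number from compound 1 to compound 3 (0.59 log units; beyond the scatter).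

The next compound is compound 4 `CC(C)c1ccc(Nc2nc(Nc3ccc(N4CCN(C)CC4)cn3)ncc2Cl)cc1`. Its change is 4-isopropylphenyl in place of 2-methoxybenzyl on a nitrogen on an aromatic ring. Compound 1 also carries a substituted phenyl on that nitrogen, 2-methylphenyl, so the steps away from compound 1 are the closest guide. These are a 3.3-fold higher number from compound 1 to compound 2 (0.52 log units; beyond the scatter) and a 3.9-fold higher number from compound 1 to compound 3 (0.59 log units; beyond the scatter), both modest and both in the same direction. Within the data shown here, only these two steps support the comparison, and no measured compound carries 4-isopropylphenyl, so what that group does here is unknown and the range must stay wide.

A modest step to a lower number in this assay is therefore expected, roughly the reverse of those two. The expected change is a 3.7-fold lower number from compound 3 to compound 4 (0.56 log units; beyond the scatter). The estimate for compound 4 is 8000 nM, with an expected range of 2500 nM to 24000 nM.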

Compound 4, concentration for 50% growth inhibition: 7020 nM
For compound 4 the middle estimate is 1.1-fold (0.06 log units) above the measured one; the measured number falls inside the stated range.
By their numbers in this assay, from the lowest: compounds 4 and 1 (each within the scatter of the next); then compounds 2 and 3 (each within the scatter of the next).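

At this nitrogen on an aromatic ring, 4-isopropylphenyl and 2-methylphenyl cannot be told apart in this assay (a 1.1-fold lower number from compound 1 to compound 4 (0.03 log units; within the scatter)), so this change of substituent and of its place on the phenyl ring leaves the number within the scatter. Among these compounds, both benzyl compounds stand apart from compound 4 (a 3.5-fold lower number from compound 2 to compound 4 (0.55 log units; beyond the scatter); a 4.2-fold lower number from compound 3 to compound 4 (0.62 log units; beyond the scatter)), and each step is modest and beyond the scatter, so across these four compounds the two substituted phenyl groups sit at the low end of the numbers and the benzyl and 2-methoxybenzyl groups at the high end, with no compound going against that split. No evidence is available to account for this split between phenyl and benzyl groups on the nitrogen.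

The compounds shown leave open how an unsubstituted phenyl, or a phenyl ring carrying an amine or a carboxylic acid, would behave on this nitrogen. Also open, from the compounds shown here alone, is whether a longer chain, such as phenylethyl, would extend the trend from phenyl to benzyl or break it.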